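Cyclobutyl to 4-fluorophenyl on the chain carbon: expected half-life

The compounds below may be only part of what the source reports. "The series", "measured", "known", "first", "only" and "open" are said of these compounds alone.

Measured compounds:
compound 1 `CC(C)=Cc1nn(CCC(C)C)c(=O)c(C2=NS(=O)(=O)c3cc(NS(C)(=O)=O)ccc3N2)c1O`: 0.55 h
compound 2 `CS(=O)(=O)Nc1ccc2c(c1)S(=O)(=O)N=C(c1c(O)c(-c3cccs3)nn(CC3CCC3)c1=O)N2`: > 1 h

In an in vitro ADME assay on microsomes from liver (Homo sapiens) for metabolic stability, tested at 5 uM (a higher number here means that the compound lasts longer, a lower number that the compound disappears faster), compound 1 gives 0.55 h. Compound 2 stands at > 1 h, which is a limit of the assay rather than a number (the limit of > 1 h in this assay, at which 1 of the 2 values shown sits). Compound 3 `CS(=O)(=O)Nc1ccc2c(c1)S(=O)(=O)N=C(c1c(O)c(-c3cccs3)nn(Cc3ccc(F)cc3)c1=O)N2` differs from compound 2 by 4-fluorophenyl in place of cyclobutyl on a saturated chain carbon bound to an aromatic nitrogen. Within the data shown here, no step between two measured compounds is available to guide this change, so the expected step of a number no higher from compound 2 to compound 3 (the limit leaves the size open) is taken as none beyond the usual scatter. Compound 3 is therefore estimated at 1 h, within a range from 0.5 h to 2 h, and the assay may again report only a limit for it.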

Compound 3, half-life: > 1 h
Compound 3 ended at the assay's limit; the forecaster's own chance of this, stated with the estimate: 45%; the middle value sits exactly at the limit.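

No step can be read from compound 2 to compound 3 in this assay, since both values are limits of the assay: the limit of > 1 h in this assay, at which 2 of the 3 values shown sit.

The compounds shown leave open the actual half-lives of compound 2 and compound 3, and so whether 4-fluorophenyl in place of cyclobutyl changes the half-life at all.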